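The source may hold more compounds than are shown below. What is called first, only, known or untested is meant among the compounds shown, and "the series" means these compounds.

For the measured compounds named here, compound 3 `NC1=NC2(CCOCC2)N(OCCCOc2ccc(Cl)cc2Cl)C(N)=N1` stands lowest of the three numbers so far in an assay on isolated protein for inhibition of Dihydrofolate reductase (Homo sapiens), read by spectrophotometry, using NADPH, with stated times of 5 s and 6 min (a lower number here means a stronger inhibitor, a higher number a weaker inhibitor), where compound 3 gives 7.46 nM; compound 2 `NC1=NC2(CCOCC2)N(OCCCOc2ccc(Cl)cc2)C(N)=N1` gives 33.6 nM and compound 1 `NC1=NC2(CCOCC2)N(OCCCOc2ccccc2)C(N)=N1` gives 86.1 nM. Compound 4 `NC1=NC2(CCOCC2)N(OCCCOc2ccc(Cl)c(Cl)c2)C(N)=N1` differs from compound 3 in one place: 3,4-dichlorophenyl in place of 2,4-dichlorophenyl on an oxygen on a saturated carbon. Going by the values given here, no measured step exchanges one dichlorophenyl for another; the steps that bear on it are the chloro additions, a 2.6-fold lower number from compound 1 to compound 2 (0.41 log units; beyond the scatter), a 4.5-fold lower number from compound 2 to compound 3 (0.65 log units; beyond the scatter) and, across both at once, a 12-fold lower number from compound 1 to compound 3 (1.06 log units; beyond the scatter). Each added chloro lowered the number, so keeping two chloro groups on the ring is expected to hold the number low, while moving one of them is expected to give no step beyond the scatter, about a 1.3-fold higher number from compound 3 to compound 4 (0.13 log units; within the scatter). Compound 4 is therefore estimated at 10 nM, within 3 nM to 35 nM.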

Compound 4, half-maximal inhibitory concentration: 8.23 nM
Compound 4: middle estimate off by 1.2-fold (0.08 log units), on the high side, and the stated range covers the measured number.
By their numbers in this assay, from the lowest: compounds 3 and 4 (each within the scatter of the next); then compound 2; then compound 1.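

The 2,4-dichlorophenyl and 3,4-dichlorophenyl groups cannot be told apart in this assay (a 1.1-fold higher number from compound 3 to compound 4 (0.04 log units; within the scatter)), so the two chloro groups need not sit in one fixed arrangement on the ring. The second chloro again counts in a new arrangement (a 4.1-fold lower number from compound 2 to compound 4 (0.61 log units; beyond the scatter)), and the gain over phenyl is kept (a 10-fold lower number from compound 1 to compound 4 (1.02 log units; beyond the scatter)). From the compounds shown here alone, whether a methoxy group or an amine on the ring could replace chloro and hold the number this low remains open, as does the effect of a longer chain. Nothing available explains why the two dichlorophenyl groups read alike.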